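A few compounds are considered here, and "the series" means these few. Any claim that something is new, unique, unknown or untested is made for them only; others in the source may bear on it.

Of the compounds shown here, two have been measured so far in a functional assay on K562 cells (Homo sapiens) for inhibition, read by trypan blue exclusion, with a stated time of 72 h; a higher number here means a weaker inhibitor, a lower number a stronger inhibitor. Compound 1 (`Cn1c(=O)c(S(=O)(=O)c2ccc(F)cc2)cc2cnc(Nc3ccc4occc4c3)nc21`) gives 5000 nM, and compound 2 (`Cn1c(=O)c(C(=O)Nc2ccc(F)cc2F)cc2cnc(Nc3ccc4[nH]ccc4c3)nc21`) gives 5000 nM. Compound 2 therefore stands level with compound 1, within the scatter. Among the compounds with values here, these two compounds differ in more than one place, so the data contain no single-change step to draw on.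

The next compound, compound 3 (`Cn1c(=O)c(S(=O)(=O)c2ccc(Cl)cc2)cc2cnc(Nc3ccc4[nH]ccc4c3)nc21`), has (4-chlorophenyl)sulfonyl in place of the (2,4-difluorophenyl)carbamoyl of compound 2, on an aromatic carbon. The change is counted as follows: (4-chlorophenyl)sulfonyl in place of (2,4-difluorophenyl)carbamoyl on an aromatic carbon.

Compound 1 also carries a sulfonyl-linked aryl group and gives 5000 nM, the same figure as the carbamoyl-bearing compound 2. That offers no sign that swapping one group for the other moves the result much. No step beyond the scatter is therefore expected in this assay, although a stronger inhibitor cannot be ruled out. The estimated change is a 1.7-fold lower number from compound 2 to compound 3 (0.22 log units; within the scatter). Compound 3 is expected at 3000 nM, with an estimated range of 500 nM to 10000 nM.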

Compound 3, half-maximal inhibitory concentration: 100 nM
Estimate against measurement, compound 3: 30-fold (1.48 log units) above; measured number outside the range, below it.
By their numbers in this assay, from the lowest: compound 3; then compounds 1 and 2 (each within the scatter of the next).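

At this aromatic carbon of the six-membered aromatic ring with 1 nitrogen, the group carried there can have a large effect in this assay: placing (4-chlorophenyl)sulfonyl in place of (2,4-difluorophenyl)carbamoyl gives a 50-fold lower number from compound 2 to compound 3 (1.70 log units; beyond the scatter). Compound 1 and compound 2 differ in more than one place, so their matching numbers gave no reading of this position alone, and the pair of compound 2 and compound 3 provides the first. The change alters both the link to the aryl ring, carbamoyl against sulfonyl, and the halogens on that ring, and no measurement available here explains the step or assigns it to either part.

A (4-chlorophenyl)carbamoyl group at the same carbon would separate the link from the halogen pattern, showing how much of the step follows the sulfonyl. Going by these compounds, whether the aryl ring is needed at all remains open, and a methylsulfonyl group or an unsubstituted phenylsulfonyl group at this carbon would address that question on the core of compound 3.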